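The source may report more compounds than this note shows. Statements on the series, on what has been measured and on what is new or still open speak of the compounds shown alone.

In an assay on isolated protein for inhibition of DNA topoisomerase 1 (Homo sapiens), with a stated time of 30 min, tested at 100 uM (on this read-out lower numbers stand for a weaker effect and higher numbers for a stronger effect at the one concentration tested), two compounds sharing one core have been measured. Compound 1, `Cc1ccc2c(=O)[nH]c(-c3ccccc3OC(F)(F)F)nc2c1`, gives 100%, and compound 2, `Cc1ccc2c(=O)[nH]c(-c3ccccc3F)nc2c1`, gives 81.2%. Within the data shown here, the only step measured so far is a number 18.8 percentage points lower from compound 1 to compound 2 (beyond the scatter), so compound 2 holds the lowest of the two numbers, with compound 1 as its nearest and higher neighbour.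

Compound 3, `Cc1ccc2c(=O)[nH]c(-c3ccccc3N(C)C)nc2c1`, is the next compound to be tested in this assay. It differs from compound 2 in one place: dimethylamino in place of fluoro on an aromatic carbon. The change again touches the aromatic carbon that carried trifluoromethoxy in compound 1 and fluoro in compound 2, so the step from compound 1 to compound 2 is the one that bears on it, and that step was modest. Among the measured compounds shown here, no measured compound carries dimethylamino, so how this group compares with fluoro or with trifluoromethoxy is not known from the data; only the direction of the earlier change, a larger group giving the higher number, offers a hint. Compound 3 is therefore expected to sit above compound 2, with a step of roughly a number 3.8 percentage points higher from compound 2 to compound 3 (within the scatter), and its estimated inhibition is 85%, within a range from 55% to 100%.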

Compound 3, a percentage reported as inhibition, at one concentration (the size of the read-out at that concentration, not a potency): 82.1%
Beside the measured number, compound 3's estimate is 2.9 percentage points above it, and the stated range covers the measured number.
By their numbers in this assay, from the lowest: compounds 2 and 3 (each within the scatter of the next); then compound 1.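

In this assay, dimethylamino in place of fluoro on this aromatic carbon, ortho to a large group, gives a number 0.9 percentage points higher from compound 2 to compound 3 (within the scatter), so compound 2 and compound 3 cannot be told apart, although the entering group has 3 heavy atoms and 1 hydrogen-bond acceptor and the leaving one has 1 heavy atom and 0 hydrogen-bond acceptors. Dimethylamino in place of trifluoromethoxy gives a number 17.9 percentage points lower from compound 1 to compound 3 (beyond the scatter), which leaves compound 1 apart from the other two and means the earlier hint, that a larger group goes with a higher number, does not hold for compound 3. Nothing available explains why these groups read as they do at this position.

Among these compounds, the three compounds cover only three groups at this one position on the shared core, so it remains open whether the reading of compound 1 depends on the oxygen link or on the fluorines of trifluoromethoxy, which a methoxy or a trifluoromethyl group would separate. Going by these compounds, it is equally open where a primary amine or a plain hydrogen on this carbon would fall relative to these compounds.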